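The compounds below may be only part of what the source reports. "The series", "measured", "known", "first", "only" and "open" are said of these compounds alone.

Compound 1 `Cc1nccn1-c1csc(Nc2ccc(S(N)(=O)=O)cc2)n1` and compound 2 `Cc1nccn1-c1csc(Nc2ccccc2)n1` share one core, and compound 2 differs from compound 1 by hydrogen in place of sulfamoyl on an aromatic carbon. In a functional assay on RKO cells (Homo sapiens) for cytotoxicity, read by resazurin assay, with a stated time of 72 h (on this read-out higher numbers stand for weaker inhibition and lower numbers for stronger inhibition), compound 1 gives only a limit of the assay, > 100000 nM. In this assay compound 2 likewise gives only a limit, > 100000 nM. The step that the two limits leave unreadable from compound 1 to compound 2 therefore has no readable size, because of the limit of > 100000 nM in this assay, at which 2 of the 3 values shown sit. Compound 3 `Cc1nc2ccccc2n1-c1csc(Nc2ccc(S(N)(=O)=O)cc2)n1` carries a different core; how its core differs from that of compound 1 is not broken down here. In this assay, within the data shown here, compound 3 gives 95000 nM, the only actual number among the three measured compounds. Compound 4 `Cc1nc2ccccc2n1-c1csc(Nc2ccccc2)n1` has not yet been measured; it differs from compound 3 by hydrogen in place of sulfamoyl on an aromatic carbon, the same change as that from compound 1 to compound 2. Since the earlier step could not be sized, the expectation rests mainly on where compound 3 already stands at 95000 nM. Compound 4 is therefore expected to show a step of about a 1.2-fold higher number from compound 3 to compound 4 (0.06 log units; within the scatter), with an estimated value near 110000 nM, likely between 50000 nM and 250000 nM, and a real chance that only a limit is reported.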

Compound 4, half-maximal inhibitory concentration: 50000 nM
Estimate against measurement, compound 4: 2.2-fold (0.34 log units) above; the range from low to high includes it.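

On the core of compound 3, putting hydrogen in place of sulfamoyl gives a 1.9-fold lower number from compound 3 to compound 4 (0.28 log units; within the scatter) in this assay, so the two compounds cannot be told apart on this read-out. On the core of compound 1, the same change gives a step that cannot be read, because compound 1 and compound 2 each give only a limit of the assay: the limit of > 100000 nM in this assay, at which 2 of the 4 values shown sit. This leaves a single sized step for the change, which shows no clear shift on the core of compound 3 but does not show whether the change acts alike on both cores, since there is no second size to compare it with.

Going by these compounds, whether another group at the same place, para to a large group, such as an amine or a carboxylic acid, would give a number clearly apart from that of compound 3 remains open. Also open, on these data alone, is whether any such group could bring the core of compound 1 to a measurable number rather than a limit.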